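Adding a Second Chlorine to Two Related Cores

The source may hold more compounds than are shown below. What is called first, only, known or untested is meant among the compounds shown, and "the series" means these compounds.

Compound 1 `ClCc1cccc(Cn2cnc3ncnc(Cl)c32)c1` and compound 2 `ClCc1ccccc1Cn1cnc2ncnc(Cl)c21` are built from the same atoms joined differently; the difference between the two cores is not broken down here. In a functional assay on SK-MEL-2 cells (Homo sapiens) for cytotoxicity, read by sulforhodamine B assay, with a stated time of 48 h (on this read-out higher numbers stand for lower toxicity in this test and lower numbers for higher toxicity in this test), compound 1 gives 6760 nM. Compound 2 reaches only the limit of the assay, > 100000 nM, so no number is known for it. Compound 3 `ClCc1cccc(Cn2cnc3nc(Cl)nc(Cl)c32)c1` arises from compound 1 by the change (chloro in place of hydrogen on an aromatic carbon), and this gave a 1.1-fold higher number from compound 1 to compound 3 (0.06 log units; within the scatter); in this assay compound 3 gives 7760 nM. Compound 4 `ClCc1ccccc1Cn1cnc2nc(Cl)nc(Cl)c21` arises from compound 2 by the same change, (chloro in place of hydrogen on an aromatic carbon). Because the measured change gave a 1.1-fold higher number from compound 1 to compound 3 (0.06 log units; within the scatter), the step from compound 2 to compound 4 is expected to be small as well, a step that the limit leaves unreadable from compound 2 to compound 4. Since compound 2 sits at the limit (the limit of > 100000 nM in this assay, at which 1 of the 3 values shown sits), compound 4 is expected to sit there too, most likely returning a limit rather than a number. The estimate for compound 4 in this assay is 150000 nM, with a range from 60000 nM to 400000 nM.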

Compound 4, concentration lethal to 50% of the cells: > 100000 nM
Compound 4 gave a limit, no number (the forecaster's own chance of this, stated with the estimate: 70%); the middle value lies beyond the limit too.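

No step can be read from compound 2 to compound 4, because each returned a limit of the assay rather than a number: the limit of > 100000 nM in this assay, at which 2 of the 4 values shown sit.

The compounds shown leave open how far past that limit compound 2 and compound 4 lie, and whether the added chloro changes anything on the core of compound 2.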